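Series notes: cyclopentyl for dimethoxypropyl on the aromatic nitrogen

The compounds below may be only part of what the source reports. "The series", "measured", "known", "first", "only" and "open" are said of these compounds alone.

Measured so far in a functional assay on HepG2 cells (Homo sapiens) for antiproliferative activity, read by CCK-8 assay, with a stated time of 72 h, tested at 8 uM; a higher number here means a stronger effect of the compound at the concentration tested, a lower number a weaker effect:
compound 1 `COC(CCn1cnc2c(NCc3ccc(C(=O)Nc4ccccc4N)cc3)nc(Cl)nc21)OC` — 34.2%
compound 2 `CC(C)n1cnc2c(Nc3cccc(Cl)c3)nc(NCOCc3ccc(/C=C/C(=O)Nc4ccccc4N)cc3)nc21` — 49.9%

Compound 1 stands lowest of the two numbers in this assay. For the measured compounds named here, compound 2 sits above it by a gap beyond the usual scatter; no single-change step between compound 1 and compound 2 is available, so only the two values themselves can be compared.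

Compound 3 `Nc1ccccc1NC(=O)c1ccc(CNc2nc(Cl)nc3c2ncn3C2CCCC2)cc1` has not yet been measured. It differs from compound 1 in one place: cyclopentyl in place of 3,3-dimethoxypropyl on an aromatic nitrogen. Going by the values given here, no measured pair shows this change, so nothing in the data fixes its direction. In the absence of such a reference, the expected step from compound 1 to compound 3 in this assay is small, a number 5.8 percentage points higher from compound 1 to compound 3 (within the scatter), and not clearly beyond the scatter in either direction.

For compound 3, the expected value in this assay is 40%, with a range from 22% to 58%.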

Compound 3, a percentage reported as inhibition, at one concentration (the size of the read-out at that concentration, not a potency): 74.9%
Compound 3: the middle estimate sits 34.9 percentage points below what was measured; the whole stated range lies below it.
By their numbers in this assay, from the lowest: compound 1; then compound 2; then compound 3.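

In this assay the group on the aromatic nitrogen proves to matter: with the rest of the molecule unchanged, cyclopentyl in place of 3,3-dimethoxypropyl gives a number 40.7 percentage points higher from compound 1 to compound 3 (beyond the scatter) at this position. For the compounds shown here, this is the first one-place comparison, and it replaces an open chain carrying oxygen with a five-membered ring of carbon only, so the loss of the oxygens and the gain of the ring arrive together. Nothing at hand accounts for the size of this step.

From the compounds shown here alone, whether the ring or the removal of the oxygens carries the step stays open; an unbranched pentyl chain or a tetrahydrofuranyl ring would separate the two. Also open, going by these compounds, is how ring size bears on the read-out, as with cyclobutyl or cyclohexyl.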